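Chloro in place of methyl in two matched pairs

The compounds below may be only part of what the source reports. "The series", "measured", "known", "first", "only" and "open" are said of these compounds alone.

Compound 1 `Cc1ccc(-c2ccc(C(=O)N[C@H](c3nc(C)c(CCO)s3)[C@@H]3CCCCN3)[nH]2)cc1F` gives 29700 nM in a toxicity assay on MT2 cells (Homo sapiens) for cytotoxicity, read by XTT assay, with a stated time of 4 days; a lower number here means that less compound is tolerated, a higher number that more compound is tolerated. Compound 2 `Cc1nc([C@@H](NC(=O)c2ccc(-c3ccc(Cl)c(F)c3)[nH]2)[C@@H]2CCCCN2)sc1CCO` carries chloro in place of methyl on an aromatic carbon and gives 16900 nM in this assay; the step between them is a 1.8-fold lower number from compound 1 to compound 2 (0.24 log units; within the scatter). Compound 3 `Cc1ccc(-c2ccc(C(=O)N[C@@H](c3nc(C)c(CCCO)s3)[C@@H]3CCCCN3)[nH]2)cc1F` gives 20600 nM in this assay; this value and those of compound 1 and compound 2 all lie within the scatter of one another. The difference between the core of compound 3 and the core of compound 1 is not broken down here.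

Compound 4 `Cc1nc([C@H](NC(=O)c2ccc(-c3ccc(Cl)c(F)c3)[nH]2)[C@@H]2CCCCN2)sc1CCCO` is not yet measured. Relative to compound 3 it shows (chloro in place of methyl on an aromatic carbon), the same change as in the measured pair, at a place described in the same words. The expected step is a 1.6-fold lower number from compound 3 to compound 4 (0.20 log units; within the scatter). This rests on the measured 1.8-fold lower number from compound 1 to compound 2 (0.24 log units; within the scatter), which stayed within the scatter, so a step of similar size and direction is assumed, with wide uncertainty. Compound 4 is therefore estimated at 13000 nM in this assay, with a range from 6000 nM to 30000 nM.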

Compound 4, half-maximal cytotoxic concentration: 12600 nM
Estimate against measurement, compound 4: 1.0-fold (0.01 log units) above; measured number inside the range.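

Chloro in place of methyl, read here as 3-fluoro-4-methylphenyl to 4-chloro-3-fluorophenyl, gives a 1.6-fold lower number from compound 3 to compound 4 (0.21 log units; within the scatter) in this assay. Set beside the earlier pair, the change carries from one core to the other with a step of similar size and the same direction, and the two steps do not differ: the same change on two cores in this assay, a 1.8-fold lower number (0.24 log units; within the scatter) from compound 1 to compound 2 and a 1.6-fold lower number (0.21 log units; within the scatter) from compound 3 to compound 4, 1.1-fold (0.03 log units) apart, within the scatter of two such steps. Among these compounds, each step lies within the scatter, however, so the pairs show only that this change leaves no readable mark on either core; they do not show a real effect of chloro on this read-out, and two cores cannot establish how it behaves across the wider series.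

The compounds shown hold only methyl and chloro at this place on the ring, which leaves open what a bromo, a methoxy or a nitrile would give there. Also open, on these data alone, is whether the same step would hold on a core bearing an amine or a carboxylic acid in place of the terminal hydroxyl.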